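Extending the amine chain of compound 2 toward compound 3

The compounds below may be only part of what the source reports. "The series", "measured", "known", "first", "only" and "open" are said of these compounds alone.

Two measured compounds share a common core. Compound 1 `CCCN1CCCN(c2nc3ccccc3n2CCOCC)CC1` carries a propyl group on a seven-membered ring amine, and in a functional assay on ileum for inhibition of histamine H1 receptor (Cavia porcellus) (on this read-out lower numbers stand for stronger inhibition and higher numbers for weaker inhibition), compound 1 gives 8.4 nM. Compound 2 `CCOCCn1c(N2CCN(CC)CC2)nc2ccccc21` carries instead an ethyl group on a six-membered ring amine; in this assay compound 2 gives 18 nM. Of the two numbers, compound 2 stands at the higher one, and the gap to compound 1 lies beyond the usual scatter; since the two compounds differ in more than one place, nothing more can be read from that pair.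

Compound 3 `CCCCN1CCN(c2nc3ccccc3n2CCOCC)CC1` keeps the six-membered ring amine of compound 2 and differs from it only in that (ethyl in place of hydrogen on a saturated chain carbon, two bonds along the chain from an amine nitrogen in a ring). Among the compounds with values here, no measured pair shows the effect of such a change. With the amine chain of compound 3 now longer than that of compound 1, a small step toward a lower number in this assay is expected for compound 3, roughly at the edge of the scatter, so that the step from compound 2 amounts to a 1.6-fold lower number from compound 2 to compound 3 (0.21 log units; within the scatter) in expectation. In this assay compound 3 is therefore estimated at 11 nM, within a range from 4 nM to 30 nM.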

Compound 3, half-maximal inhibitory concentration: 15 nM
The estimate for compound 3 lay 1.4-fold (0.13 log units) below the measured number; the range from low to high includes it.
By their numbers in this assay, from the lowest: compounds 1, 3 and 2 (each within the scatter of the next, the first and the last beyond it).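

In this assay, within the data shown here, compounds 2 and 3 form the first pair that differs in one place, and the step reads a 1.2-fold lower number from compound 2 to compound 3 (0.08 log units; within the scatter). On a saturated chain carbon, two bonds along the chain from an amine nitrogen in a ring, ethyl in place of hydrogen therefore leaves the number within the scatter, so this read-out does not separate the ethyl of compound 2 from the butyl of compound 3. Nothing available bears on why these two numbers stand so close.

The compounds shown leave open how a longer chain such as hexyl, or a chain ending in a hydroxyl group or a phenyl ring, would read at this position in this assay, as this single step gives no trend along the chain. Among these compounds, they also leave open whether the same change would read alike on the seven-membered ring amine of compound 1, which carries a propyl group, as no step on that ring amine is available for comparison.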